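A longer chain on compound 3: what dose to expect

A few compounds are considered here, and "the series" means these few. Any claim that something is new, unique, unknown or untested is made for them only; others in the source may bear on it.

Measured so far:
compound 1 `CCCCCCCCCCCCCCC1(C(=O)OCC(O)CO)CO1` — 5 mg/kg
compound 2 `CCCCCCCCCCCCCCC1(C(=O)OCCCC)CO1` — 1.5 mg/kg
compound 3 `CCCCCCC1(C(=O)OC)CO1` — 10 mg/kg

In a functional assay on the whole organism with Rattus norvegicus as the target, in the glucose tolerance test (a lower number here means that less compound is needed, a higher number that more compound is needed for the effect), compound 3 gives 10 mg/kg, the highest of the three numbers. Its nearest neighbour is compound 1, whose 5 mg/kg lies within the scatter of compound 3, so the two cannot be ordered. Compound 2, with 1.5 mg/kg, lies beyond the scatter and is the lowest of the three. For the measured compounds named here, the one step between measured compounds that differ in a single place, a 3.3-fold lower number from compound 1 to compound 2 (0.52 log units; beyond the scatter), concerns the ester side only and does not touch the chain.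

Compound 4 `CCCCCCCCCCCC1(C(=O)OC)CO1` differs from compound 3 by pentyl in place of hydrogen on a saturated chain carbon, six bonds along the chain from a saturated ring carbon. Going by the values given here, no measured pair isolates this change. Compounds 1 and 2 both carry a longer chain than compound 3 and both give lower numbers, but they also differ from compound 3 in the ester, so their values show only a loose hint in that direction. Given this, compound 4 is expected to give a lower number than compound 3, with a step of a 2.0-fold lower number from compound 3 to compound 4 (0.30 log units; within the scatter) of uncertain size. The estimate for compound 4 in this assay is 5 mg/kg, with a range from 2 mg/kg to 15 mg/kg.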

Compound 4, minimum effective dose: 10 mg/kg
Compound 4: the middle estimate sits 2.0-fold (0.30 log units) below what was measured; the measured number falls inside the stated range.
By their numbers in this assay, from the lowest: compound 2; then compounds 1, 3 and 4 (each within the scatter of the next).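

In this assay, for the compounds shown here, pentyl in place of hydrogen on a saturated chain carbon, six bonds along the chain from a saturated ring carbon, gives no change at the digits printed from compound 3 to compound 4 (within the scatter) and provides the first pair in which the chain changes while the ester stays the same. The earlier compounds shown here could not show this, as compounds 1 and 2 differ from compound 3 in both chain and ester; this pair shows that, with the ester held constant, going from methyl to hexyl at this place produces no change beyond the scatter in the dose needed. No measurement here offers an explanation for this flat result.

The compounds shown leave open whether the still longer chain carried by compounds 1 and 2 would lower the dose on the ester of compounds 3 and 4, and so how much of the low number of compound 2 belongs to its chain and how much to its ester. They also leave open how this position would respond to a chain ending in a carboxylic acid or an amine.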